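A few compounds are considered here, and "the series" means these few. Any claim that something is new, unique, unknown or untested is made for them only; others in the source may bear on it.

Measured so far in a functional assay on HT-29 cells (Homo sapiens) for inhibition, read by luminescence and CellTiter-Glo, with a stated time of 10 h; a lower number here means that less compound is needed, a higher number that more compound is needed for the effect:
Compound 1 `CN1C(=S)[C@@H](NC(=O)c2n[nH]c(Cc3ccccc3)n2)COc2ncccc21`: > 10000 nM, a limit.
Compound 2 `CN1C(=S)[C@H](NC(=O)c2n[nH]c(Cc3ccccc3)n2)COc2ncccc21`: > 10000 nM, a limit.
Compound 3 `Cc1ccc2c(n1)OC[C@@H](NC(=O)c1n[nH]c(Cc3ccccc3)n1)C(=S)N2C`: 2020 nM.

Compound 2 has no number of its own and stands at the limit of > 10000 nM in this assay, at which 2 of the 3 values shown sit. Compound 4 `Cc1cnc2c(c1)N(C)C(=S)[C@H](NC(=O)c1n[nH]c(Cc3ccccc3)n1)CO2` departs from compound 2 by one change: methyl in place of hydrogen on an aromatic carbon. The measured step that the two limits leave unreadable from compound 1 to compound 2 gives no guide. Among the measured compounds shown here, the only readable guide is an at least 4.9-fold lower number from compound 2 to compound 3 (0.69 log units; beyond the scatter), which is also methyl in place of hydrogen on an aromatic carbon, although compound 3 carries its methyl at a different place from compound 4. A lower number of similar size is therefore expected in this assay, with less certainty about its extent. The expected step is an at least 2.8-fold lower number from compound 2 to compound 4 (0.45 log units; beyond the scatter). The estimated value for compound 4 is 3500 nM, with an expected range from 1000 nM to 10000 nM.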

Compound 4, half-maximal effective concentration: 3400 nM
Beside the measured number, compound 4's estimate is 1.0-fold (0.01 log units) above it; measured number inside the range.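

In this assay, the methyl on this aromatic carbon, two atoms from the ring nitrogen, brings an at least 2.9-fold lower number from compound 2 to compound 4 (0.46 log units; beyond the scatter). Compound 3 carries its methyl at a different place, so a measured number is now reached with methyl at two places rather than one. The step remains a minimum, not a full size, because compound 2 has only a limit: the limit of > 10000 nM in this assay, at which 2 of the 4 values shown sit.

From the compounds shown here alone, whether an ethyl, a methoxy or a chlorine in place of this methyl would move the number further stays open.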